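A few compounds are considered here, and "the series" means these few. Any claim that something is new, unique, unknown or untested is made for them only; others in the source may bear on it.

Going by the values given here, compound 3 `N#CC1=C(N)Oc2c(N)cc3nc4ccccc4nc3c2C12C(=O)N(Cc1cnnn1-c1ccccc1Cl)c1ccccc12` is the only member of the set with a number in a functional assay on A549 cells (Homo sapiens) for antiproliferative activity, read by MTT assay, with a stated time of 48 h; on this read-out higher numbers stand for weaker inhibition and lower numbers for stronger inhibition: compound 3 gives 29800 nM. Compound 1 `CCOc1ccccc1-n1nncc1CN1C(=O)C2(C(C#N)=C(N)Oc3c2c2nc4ccccc4nc2c2ccccc32)c2ccccc21` sits at a limit, > 50000 nM, in this assay. Compound 2 `Cc1ccc(-n2nncc2CN2C(=O)C3(C(C#N)=C(N)Oc4c3c3nc5ccccc5nc3c3ccccc43)c3ccccc32)cc1Cl` likewise sits at a limit, > 50000 nM. From the compounds shown here alone, the step from compound 1 to compound 2 is a step that the two limits leave unreadable from compound 1 to compound 2, so its size is unknown because of the limit of > 50000 nM in this assay, at which 2 of the 3 values shown sit. Compound 4 `Cc1ccc(-n2nncc2CN2C(=O)C3(C(C#N)=C(N)Oc4c(N)cc5nc6ccccc6nc5c43)c3ccccc32)cc1Cl` differs from compound 3 by 3-chloro-4-methylphenyl in place of 2-chlorophenyl on an aromatic nitrogen. Among the compounds with values here, that same change is the only measured step bearing on it, and it gave no readable size, so no shift beyond the scatter is expected. For compound 4 the expected step is a 1.3-fold higher number from compound 3 to compound 4 (0.13 log units; within the scatter). Compound 4 is therefore estimated at 40000 nM, within 15000 nM to 110000 nM.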

Compound 4, half-maximal inhibitory concentration: 11800 nM
The estimate for compound 4 lay 3.4-fold (0.53 log units) above the measured number; measured number outside the range, below it.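

On the aromatic nitrogen, the aryl group now gives a readable change in this assay: 3-chloro-4-methylphenyl in place of 2-chlorophenyl gives a 2.5-fold lower number from compound 3 to compound 4 (0.40 log units; beyond the scatter). The earlier step at this position, between compound 1 and compound 2, cannot be read because both compounds sit at a limit: the limit of > 50000 nM in this assay, at which 2 of the 4 values shown sit.

This readable step rests on a single pair, on the core of compound 3. From the compounds shown here alone, whether the same change moves the number on the core of compound 1 stays open, as does the result of an amine or a carboxylic acid in place of the chlorine on this phenyl ring.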